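Working notes on a paw edema series

The source may hold more compounds than are shown below. What is called first, only, known or untested is meant among the compounds shown, and "the series" means these compounds.

Measured so far:
compound 1 `CCn1c(SCC(=O)Nc2ccc(C(C)=O)cc2)nnc1-c1ccc(OC)c(OC)c1`: 59%
compound 2 `C=CCn1c(SCC(=O)Nc2ccc(C(C)=O)cc2)nnc1-c1ccc(OC)c(OC)c1`: 57%
compound 3 `CCn1c(SCC(=O)Nc2ccc(C(C)=O)cc2)nnc1-c1cc(OC)c(OC)c(OC)c1`: 50%

All three numbers come from a functional assay on the whole organism (strain albino) for inhibition, with Rattus norvegicus as the target, read by paw edema, with stated times of 30 min and 2 h, at a dose of 0.28 mmol/kg by the oral route; on this read-out lower numbers stand for less inhibition and higher numbers for more inhibition at the one dose given (going by the name of the read-out). Compound 1 gives the highest of the three numbers, but its two neighbours sit within the scatter of it: a number 2 percentage points lower from compound 1 to compound 2 (within the scatter) and a number 9 percentage points lower from compound 1 to compound 3 (within the scatter). Nothing here separates the three compounds beyond the usual spread of repeated measurement.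

Compound 4 `CCn1c(SCC(=O)Nc2ccc(C(C)=O)cc2)nnc1-c1ccccc1` is not yet measured. It differs from compound 1 in one place: phenyl in place of 3,4-dimethoxyphenyl on an aromatic carbon.

Within the data shown here, of the measured steps, only the one from compound 1 to compound 3 touches the same aromatic ring, and there the added methoxy gave a number 9 percentage points lower from compound 1 to compound 3 (within the scatter). The step from compound 1 to compound 2 changes the ethyl group instead and gave a number 2 percentage points lower from compound 1 to compound 2 (within the scatter). Among the measured compounds shown here, neither step moves the read-out beyond the scatter, and no measured pair removes a methoxy group, so the change to compound 4 rests on little. The expectation is therefore a step within the scatter, a number 6 percentage points lower from compound 1 to compound 4 (within the scatter), with no direction claimed.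

For compound 4 the estimate in this assay is 53%, expected to lie between 38% and 66%.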

Compound 4, a percentage reported as inhibition, in the whole organism at one dose (the size of the read-out at that dose, not a potency): 53%
Compound 4: the middle estimate sits on the measured number at the digits printed; low and high end bracket the measured number.
By their numbers in this assay, from the lowest: compounds 3, 4, 2 and 1 (each within the scatter of the next).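

In this assay, removing both methoxy groups from the ring on the aromatic carbon between two ring nitrogen atoms gives a number 6 percentage points lower from compound 1 to compound 4 (within the scatter), so at this one dose the read-out does not show a dependence on the 3,4-dimethoxyphenyl group, and phenyl, with no hydrogen-bond acceptors, serves within the scatter. Among these compounds, until now the only change on this ring was the addition of a methoxy group, a number 9 percentage points lower from compound 1 to compound 3 (within the scatter); with the new step, both adding to and stripping this ring leave the read-out within the scatter, which holds for these compounds only and says nothing of potency, since only one dose is given. No measurement on hand explains why the number holds across these rings, and the data offer no basis for a mechanism.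

From the compounds shown here alone, it remains open whether an aromatic ring is needed at this position at all, for instance whether cyclohexyl in place of phenyl would keep the read-out within the scatter of compound 4. Also open, going by these compounds, is whether an amine or a carboxylic acid on the phenyl ring, or a butyl chain in place of the ethyl group, would move the number beyond the scatter.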